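Swapping a chlorophenyl for a methylpyrazolyl on a chromenone

A few compounds are considered here, and "the series" means these few. Any claim that something is new, unique, unknown or untested is made for them only; others in the source may bear on it.

Measured so far:
compound 1, `NS(=O)(=O)c1ccc(-c2oc3ccccc3c(=O)c2-c2ccc(F)cc2)cc1`, 67%
compound 2, `CS(=O)(=O)c1ccc(-c2oc3ccccc3c(=O)c2-c2cccc(Cl)c2)cc1`, < 5%
compound 3, `COc1ccc(-c2c(-c3ccc(S(C)(=O)=O)cc3)oc3ccccc3c2=S)cc1`, < 5%

The three measured compounds share a fused core and a sulfonyl-bearing aryl group; they were tested in an assay on isolated protein for inhibition of prostaglandin G/H synthase 1 (Mus musculus), tested at 10 ug/mL; a lower number here means less inhibition, a higher number more inhibition at the concentration tested (going by the name of the read-out). Compound 1 gives 67%. Compound 2 gives only a limit of the assay, < 5%, and so no number for it is known. Compound 3 likewise gives only a limit, < 5%. The picture is dominated by the limit of < 5% in this assay, at which 2 of the 3 values shown sit. No two of the measured compounds differ in a single place, so no measured step can be read from them; one can only say that compound 1 lies clearly above the two limits.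

Compound 4, `Cn1cc(-c2c(-c3ccc(S(C)(=O)=O)cc3)oc3ccccc3c2=O)cn1`, has not been measured. It differs from compound 2 by 1-methyl-1H-pyrazol-4-yl in place of 3-chlorophenyl on an aromatic carbon. Since compound 2 stands at a limit, the step cannot be anchored from below, and no measured change of this kind exists among the three compounds. The step is expected to be small: a number at least 3 percentage points higher from compound 2 to compound 4 (that floor lies within the scatter) is estimated to stay within the scatter. Compound 4 is thus expected to give 8%, with a range from 0% to 25%.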

Compound 4, a percentage reported as inhibition, at one concentration (the size of the read-out at that concentration, not a potency): < 5%
Compound 4 gave a limit, no number; the forecaster's own chance of this, stated with the estimate: 60%; at least 3 percentage points between middle value and limit.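

In this assay compound 4 gives < 5%, which is a limit of the assay and not a number. Compound 2 also stands at a limit, so no step from compound 2 to compound 4 can be read: the limit of < 5% in this assay, at which 3 of the 4 values shown sit.

The compounds shown leave open whether 1-methyl-1H-pyrazol-4-yl in place of 3-chlorophenyl changes the inhibition at all.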